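Trifluoromethyl in Place of Fluoro: An Expected Outcome

The source may hold more compounds than are shown below. What is called first, only, known or untested is meant among the compounds shown, and "the series" means these compounds.

Two compounds have been measured in a functional assay on DU-145 cells (Homo sapiens) for cytotoxicity, read by MTT assay, with a stated time of 72 h; a higher number here means a weaker inhibitor, a lower number a stronger inhibitor:

Compound 1, `COc1ccc(C(=O)c2cc(OC)c(OC)c(OC)c2)cc1NC(=O)/C=C/c1ccc(C(F)(F)F)cc1`, gives 4300 nM.
Compound 2, `COc1cc(C(=O)c2cc(OC)c(OC)c(OC)c2)cc(NC(=O)/C=C/c2ccc(F)cc2)c1OC`, gives 6700 nM.

Compound 2 has the higher of the two numbers, but the gap to compound 1 is within the usual scatter of such measurements, so the two cannot be told apart on these data. Among the compounds with values here, the two compounds also differ in more than one place, so no single step between them is counted here.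

Compound 3, `COc1cc(C(=O)c2cc(OC)c(OC)c(OC)c2)cc(NC(=O)/C=C/c2ccc(C(F)(F)F)cc2)c1OC`, has not yet been measured. It shares the core of compound 2 and differs from it in one place only: trifluoromethyl in place of fluoro on an aromatic carbon. Within the data shown here, the trifluoromethyl group is the one carried by compound 1, which gives 4300 nM on its own core, a number close to that of compound 2. Nothing here points to a change beyond the scatter in this assay, and the step from compound 2 to compound 3 is expected to be small, a 1.3-fold lower number from compound 2 to compound 3 (0.13 log units; within the scatter). Compound 3 is therefore estimated at 5000 nM, with a likely range from 2000 nM to 15000 nM.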

Compound 3, half-maximal inhibitory concentration: 5100 nM
Estimate against measurement, compound 3: 1.0-fold (0.01 log units) below, and the stated range covers the measured number.
By their numbers in this assay, from the lowest: compounds 1, 3 and 2 (each within the scatter of the next).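

Swapping fluoro for trifluoromethyl on the phenyl ring at the end of the ethenyl chain, with the rest of the molecule held fixed, gives in this assay a 1.3-fold lower number from compound 2 to compound 3 (0.12 log units; within the scatter) and so shows that this position takes the larger group, four heavy atoms in place of one, with no readable shift in the number. The second step, methoxy in place of hydrogen on an aromatic carbon with the trifluoromethyl group kept, gives a 1.2-fold higher number from compound 1 to compound 3 (0.07 log units; within the scatter) and is also unresolved, something the earlier pair could not show because those two compounds differed in more than one place. No measurement on hand offers any reason why the numbers stay so close.

On these data alone, all three compounds carry fluorine in the group at this position, so it remains open whether an amine, a carboxylic acid or a plain hydrogen there would move the number beyond the scatter. As far as these compounds go, a longer chain in place of trifluoromethyl is equally open, as is whether the same small steps would appear on other cell lines.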